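Cyclohexyl to isobutyl on a shared core

A few compounds are considered here, and "the series" means these few. Any claim that something is new, unique, unknown or untested is made for them only; others in the source may bear on it.

Measured in a functional assay (Nicotiana tabacum); on this read-out lower numbers stand for stronger inhibition and higher numbers for weaker inhibition:
Compound 1 `CNc1nc(SC)nc2ncccc12`: 2920 nM
Compound 2 `CSc1nc(NC2CCCCC2)c2cccnc2n1`: 5650 nM

In this assay compound 2, at 5650 nM, lies within the scatter of compound 1. Compound 3 `CSc1nc(NCC(C)C)c2cccnc2n1` has not yet been measured. It carries isobutyl in place of cyclohexyl on a nitrogen on an aromatic ring. Within the data shown here, the one measured step at this place is a 1.9-fold higher number from compound 1 to compound 2 (0.29 log units; within the scatter), and it replaced methyl with cyclohexyl. That step gives no ground for expecting more than scatter from the new change. The expected step is a 1.4-fold lower number from compound 2 to compound 3 (0.15 log units; within the scatter), which would stay within the scatter. For compound 3 the estimated value is 4000 nM, with an expected range from 1500 nM to 11000 nM.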

Compound 3, half-maximal inhibitory concentration: 540 nM
Compound 3: middle estimate off by 7.4-fold (0.87 log units), on the high side, and the stated range ends above it.
By their numbers in this assay, from the lowest: compound 3; then compounds 1 and 2 (each within the scatter of the next).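

In this assay, this position proves able to move the read-out well beyond the scatter: replacing cyclohexyl with isobutyl gives a 10-fold lower number from compound 2 to compound 3 (1.02 log units; beyond the scatter). Compound 3 also stands apart from the methyl compound, with a 5.4-fold lower number from compound 1 to compound 3 (0.73 log units; beyond the scatter), so the open-chain isobutyl gives a lower number than either of the two groups that could not be told apart. Nothing on hand explains this result.

The compounds shown leave open whether the branching of isobutyl matters, which a straight butyl chain would test. They also leave open how an amine at the end of the chain would read out.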